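A Benzyl Ether Replacing the Benzamide

A few compounds are considered here, and "the series" means these few. Any claim that something is new, unique, unknown or untested is made for them only; others in the source may bear on it.

Measured so far:
- compound 1 `Cc1nn(-c2ncnc3nc[nH]c23)c2c1C(OC1CCCC1)CC(=O)N2`: 62 nM
- compound 2 `Cc1nn(-c2ncnc3nc[nH]c23)c2c1C(C(=O)N(C)c1nccs1)CC(=O)N2`: 3300 nM
- compound 3 `Cc1nn(-c2ncnc3nc[nH]c23)c2c1C(NC(=O)c1ccccc1)CC(=O)N2`: 158 nM

All three share one core and differ only in the group attached to a saturated ring carbon. In a functional assay on HEK293 cells for agonist activity at G-protein coupled receptor 39 (Homo sapiens), read by scintillation proximity assay and inositol phosphate accumulation, with a stated time of 75 min (on this read-out lower numbers stand for an effect already at smaller amounts and higher numbers for an effect only at larger amounts of compound), compound 3 gives 158 nM and stands second highest of the three numbers: a 2.5-fold higher number from compound 1 to compound 3 (0.41 log units; beyond the scatter), while a 21-fold lower number from compound 2 to compound 3 (1.32 log units; beyond the scatter).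

Compound 4 `Cc1nn(-c2ncnc3nc[nH]c23)c2c1C(OCc1ccccc1Cl)CC(=O)N2` is the next compound. It differs from compound 3 as follows: (2-chlorobenzyl)oxy in place of benzamido on a saturated ring carbon. The change brings back an ether linkage, as in compound 1, while keeping an aromatic ring, as in compound 3. Among the measured compounds shown here, no measured step covers exactly this exchange. The step that bears on it most closely is the modest one from the ether of compound 1 to the amide of compound 3, a 2.5-fold higher number from compound 1 to compound 3 (0.41 log units; beyond the scatter); the large step of a 21-fold lower number from compound 2 to compound 3 (1.32 log units; beyond the scatter) shows how strongly this position can shift the number. A modest move back toward the ether of compound 1 is therefore expected, that is a 2.0-fold lower number from compound 3 to compound 4 (0.30 log units; within the scatter) in this assay. Compound 4 is estimated at 80 nM, with a likely range from 25 nM to 250 nM.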

Compound 4, half-maximal effective concentration: 47 nM
Compound 4: middle estimate off by 1.7-fold (0.23 log units), on the high side; low and high end bracket the measured number.
By their numbers in this assay, from the lowest: compounds 4 and 1 (each within the scatter of the next); then compound 3; then compound 2.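

Exchanging benzamido for (2-chlorobenzyl)oxy on the saturated ring carbon gives a 3.4-fold lower number from compound 3 to compound 4 (0.53 log units; beyond the scatter) in this assay, and exchanging the methyl(1,3-thiazol-2-yl)carbamoyl group for it gives a 70-fold lower number from compound 2 to compound 4 (1.85 log units; beyond the scatter), so a group with no hydrogen-bond donor can do better here than the benzamido group, which has one. Among the ethers, 2-chlorobenzyl in place of cyclopentyl on the oxygen gives a 1.3-fold lower number from compound 1 to compound 4 (0.12 log units; within the scatter), which means that this position accepts either a saturated ring or an aromatic ring on the oxygen without a change that can be told from the scatter. Nothing available here accounts for these differences.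

On these data alone, the step from benzamido to (2-chlorobenzyl)oxy alters the link and adds the chlorine at once, so the share of each stays unknown, and a plain benzyl ether would be needed to separate them. As far as these compounds go, it also remains open whether the oxygen itself matters, which a benzylamino group in its place would test, and whether a longer chain such as 2-phenylethoxy fits as well.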